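The compounds below may be only part of what the source reports. "The series", "measured", "known", "first", "only" and "open" are said of these compounds alone.

Measured in a functional assay on HL-60 cells (Homo sapiens) for cytotoxicity, read by luminescence and CellTiter-Glo, with a stated time of 3 days; a higher number here means a weaker inhibitor, a lower number a stronger inhibitor:
- compound 1 `O=C(Nc1ccc(Cl)cc1Cl)c1cc(F)ccc1O`: 890 nM
- compound 2 `O=C(Nc1ccc([N+](=O)[O-])cc1)c1cc(F)ccc1O`: 520 nM

Compound 2 and compound 1 stand within the scatter of each other. Compound 3 `O=C(Nc1ccc([N+](=O)[O-])cc1Cl)c1cc(F)ccc1O` has chloro in place of hydrogen on an aromatic carbon of compound 2, ortho to a large group and meta to a nitro group (chloro in place of hydrogen on an aromatic carbon). Among the compounds with values here, no measured pair isolates this change. Compound 1, which also carries chloro, gives 890 nM. A small move towards a lower number in this assay is expected, hardly beyond the scatter. The expected size is a 1.7-fold lower number from compound 2 to compound 3 (0.24 log units; within the scatter). For compound 3 the estimated value is 300 nM, with an expected range of 120 nM to 750 nM.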

Compound 3, half-maximal inhibitory concentration: 280 nM
For compound 3 the middle estimate is 1.1-fold (0.03 log units) above the measured one; low and high end bracket the measured number.
By their numbers in this assay, from the lowest: compounds 3, 2 and 1 (each within the scatter of the next, the first and the last beyond it).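

In this assay, chloro in place of hydrogen, ortho to a large group and meta to a nitro group, gives a 1.9-fold lower number from compound 2 to compound 3 (0.27 log units; within the scatter), so this position accepts chloro, but no gain can be claimed. Within the data shown here, with chloro held at that carbon, nitro in place of chloro on an aromatic carbon gives a 3.2-fold lower number from compound 1 to compound 3 (0.50 log units; beyond the scatter), the only step here beyond the scatter, and a modest one. Nothing available explains either step.

From the compounds shown here alone, whether a methyl group or an amine at the chloro position would match chloro remains open. So does whether a nitrile or a carboxylic acid could stand in for the nitro group.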